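Benzyloxy variation on a piperazinyl isoxazole antiproliferative series

The source may hold more compounds than are shown below. What is called first, only, known or untested is meant among the compounds shown, and "the series" means these compounds.

Measured compounds:
compound 1, `N#Cc1ccc(COc2ccc(-c3cc(CN4CCN(Cc5ccc(C(F)(F)F)cc5)CC4)no3)cc2)cc1`, 4300 nM
compound 2, `Fc1ccccc1COc1ccc(-c2cc(CN3CCN(Cc4ccc(C(F)(F)F)cc4)CC3)no2)cc1`, 3100 nM
compound 3, `Fc1cccc(COc2ccc(-c3cc(CN4CCN(Cc5ccc(C(F)(F)F)cc5)CC4)no3)cc2)c1`, 2900 nM

All three values come from a functional assay on Mahlavu cells (Homo sapiens) for antiproliferative activity, read by sulforhodamine B assay, with a stated time of 72 h; a higher number here means a weaker inhibitor, a lower number a stronger inhibitor. Compound 3 holds the lowest number of the three, yet the steps of a 1.1-fold lower number from compound 2 to compound 3 (0.03 log units; within the scatter) and a 1.5-fold lower number from compound 1 to compound 3 (0.17 log units; within the scatter) both sit within the scatter, so no order among them is established. The step of a 1.4-fold lower number from compound 1 to compound 2 (0.14 log units; within the scatter) is likewise within the scatter.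

Compound 4, `COc1cc(COc2ccc(-c3cc(CN4CCN(Cc5ccc(C(F)(F)F)cc5)CC4)no3)cc2)cc(OC)c1OC`, differs from compound 3 in one place: 3,4,5-trimethoxyphenyl in place of 3-fluorophenyl on a saturated chain carbon bound to an oxygen on an aromatic ring. Among the measured compounds shown here, no measured step involves a trimethoxyphenyl group, so the bearing of the three small steps is indirect; they show only that exchanging the aryl group at this position has so far left this assay essentially unchanged. On that basis no step beyond the scatter is expected, although the larger change leaves more room for movement. Compound 4 is therefore estimated at 2500 nM, with a range of 800 nM to 8000 nM, which would mean an expected step of a 1.2-fold lower number from compound 3 to compound 4 (0.06 log units; within the scatter).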

Compound 4, half-maximal inhibitory concentration: 5800 nM
Compound 4: the middle estimate sits 2.3-fold (0.37 log units) below what was measured; the range from low to high includes it.
By their numbers in this assay, from the lowest: compounds 3, 2, 1 and 4 (each within the scatter of the next).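

Even 3,4,5-trimethoxyphenyl, with 12 heavy atoms and 3 hydrogen-bond acceptors, does not move this position beyond the scatter in this assay (steps: a 2.0-fold higher number from compound 3 to compound 4 (0.30 log units; within the scatter); a 1.9-fold higher number from compound 2 to compound 4 (0.27 log units; within the scatter); a 1.3-fold higher number from compound 1 to compound 4 (0.13 log units; within the scatter)). The aryl group on the saturated chain carbon bound to an oxygen on an aromatic ring has now been varied more widely, with no order established among the four compounds. Nothing available explains this result.

Going by these compounds, whether a carboxylic acid or an amine on this aryl ring would give a step beyond the scatter remains open. So does the effect of a longer chain in place of the aryl group.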